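Methoxy to hydroxy: from compound 2 to compound 3

The compounds below may be only part of what the source reports. "The series", "measured", "known", "first", "only" and "open" are said of these compounds alone.

In a functional assay on HL-60 cells (Homo sapiens) for antiproliferative activity, read by MTT assay, with a stated time of 48 h (on this read-out higher numbers stand for weaker inhibition and lower numbers for stronger inhibition), compound 1 (`CC(=O)OC/C1=C/C[C@](C)(CCC=C(C)C)/C=C/[C@@H](OC(=O)C=C(C)C)[C@](C)(O)/C=C/C1=O`) gives 2950 nM and compound 2 (`COC/C1=C/C[C@](C)(CCC=C(C)C)/C=C/[C@@H](OC(=O)C=C(C)C)[C@](C)(OC)/C=C/C1=O`) gives 4050 nM. These two values lie within the scatter of each other, so neither compound stands apart on this read-out.

Compound 3 (`COC/C1=C/C[C@](C)(CCC=C(C)C)/C=C/[C@@H](OC(=O)C=C(C)C)[C@](C)(O)/C=C/C1=O`) derives from compound 2 by one change: hydrogen in place of methyl on an oxygen on a saturated carbon, methoxy to hydroxy (hydrogen in place of methyl on an oxygen on a saturated carbon). Going by the values given here, no measured step isolates this change. Among the compounds with values here, the only guide is the narrow span of the two values, with compound 1 at 2950 nM and compound 2 at 4050 nM, so no shift beyond the scatter is expected in this assay. The expected step, a 1.2-fold lower number from compound 2 to compound 3 (0.08 log units; within the scatter), is a small one toward stronger inhibition and stays within the scatter. The estimate for compound 3 is 3400 nM, with an expected range of 1700 nM to 7000 nM.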

Compound 3, half-maximal inhibitory concentration: 3070 nM
The estimate for compound 3 lay 1.1-fold (0.04 log units) above the measured number, and the stated range covers the measured number.
By their numbers in this assay, from the lowest: compounds 1, 3 and 2 (each within the scatter of the next).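

In this assay, methoxy to hydroxy, with hydrogen in place of methyl on an oxygen on a saturated carbon, gives a 1.3-fold lower number from compound 2 to compound 3 (0.12 log units; within the scatter) and so does not separate the two compounds on this read-out. Going by these compounds alone, compound 3 also gives the first reading of a change at the other oxygen on a saturated carbon: methyl in place of acetyl gives a 1.0-fold higher number from compound 1 to compound 3 (0.02 log units; within the scatter) and likewise leaves the two compounds inseparable. Both oxygens therefore tolerate these particular exchanges in this assay, and no measurement on hand helps to explain that tolerance.

As far as these compounds go, it remains open whether a benzoyl group or a longer alkyl chain on either oxygen would move the number beyond the scatter. From the compounds shown here alone, it is equally open whether an amine in place of the hydroxy would do so, or whether a carboxylic acid in place of the acetyl ester would.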